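Carboxy replacement at one aromatic carbon: working notes

A few compounds are considered here, and "the series" means these few. Any claim that something is new, unique, unknown or untested is made for them only; others in the source may bear on it.

Measured in a functional assay on P388 cells (Mus musculus) for cytotoxicity; on this read-out lower numbers stand for stronger inhibition and higher numbers for weaker inhibition:
- compound 1 `Cc1cc(-c2c(F)cc3c(=O)c(Cc4ccc(Cl)cc4)cn(C4CC4)c3c2F)cc(C)n1`: 20000 nM
- compound 2 `Cc1cc(-c2c(F)cc3c(=O)c(Cc4ccc(O)cc4O)cn(C4CC4)c3c2F)cc(C)n1`: 210 nM
- compound 3 `Cc1cc(-c2c(F)cc3c(=O)c(C(=O)O)cn(C4CC4)c3c2F)cc(C)n1`: 29000 nM

Compound 3 gives 29000 nM, the highest number of the three, although compound 1 lies within the scatter of it: a 1.5-fold higher number from compound 1 to compound 3 (0.16 log units; within the scatter). Compound 2 stands well apart: a 140-fold higher number from compound 2 to compound 3 (2.14 log units; beyond the scatter). The next structure, compound 4 `Cc1cc(-c2c(F)cc3c(=O)c(Cc4c[nH]cn4)cn(C4CC4)c3c2F)cc(C)n1`, differs from compound 3 as follows: (1H-imidazol-4-yl)methyl in place of carboxy on an aromatic carbon. In words, (1H-imidazol-4-yl)methyl stands in place of carboxy on an aromatic carbon.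

The two measured steps away from the carboxy group disagree. Both of the groups that replaced it end in an aromatic ring, yet compound 1 stays level with compound 3, while compound 2 does not. The ring substituents alone separate those two: a 95-fold lower number from compound 1 to compound 2 (1.98 log units; beyond the scatter). Within the data shown here, no measured compound carries an imidazole, so neither outcome can be ruled out for compound 4. A step of intermediate size towards a lower number is therefore expected, with wide uncertainty. The expected change is a 9.7-fold lower number from compound 3 to compound 4 (0.99 log units; beyond the scatter). For compound 4 the estimated value is 3000 nM, with an expected range from 400 nM to 25000 nM.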

Compound 4, half-maximal inhibitory concentration: 390 nM
For compound 4 the middle estimate is 7.7-fold (0.89 log units) above the measured one, and the stated range ends above it.
By their numbers in this assay, from the lowest: compounds 2 and 4 (each within the scatter of the next); then compounds 1 and 3 (each within the scatter of the next).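

In this assay, the step to (1H-imidazol-4-yl)methyl on this aromatic carbon (a 74-fold lower number from compound 3 to compound 4 (1.87 log units; beyond the scatter)) shows that the large separation from the carboxy compound does not depend on the 2,4-dihydroxybenzyl group of compound 2 alone, since a one-carbon link to a five-membered aromatic ring with 2 hetero atoms also gives it. The two rings on the saturated chain carbon cannot be separated in this assay (a 1.9-fold higher number from compound 2 to compound 4 (0.27 log units; within the scatter)), although one is a six-membered carbon ring bearing two hydroxy groups and the other is an imidazole. Having a ring on that chain carbon is still not enough in itself, as compound 1 goes against any such pattern: its 4-chlorophenyl ring stays clearly apart from the imidazole (a 51-fold lower number from compound 1 to compound 4 (1.71 log units; beyond the scatter)).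

Still open, on these data alone, is how a 4-hydroxybenzyl group, a pyridin-3-ylmethyl group or an aminoethyl chain at the same aromatic carbon would compare with the imidazole and the 2,4-dihydroxyphenyl ring. Nothing available explains why these groups give such different numbers.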